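Aryl ketone variation on the shared chromene core

A few compounds are considered here, and "the series" means these few. Any claim that something is new, unique, unknown or untested is made for them only; others in the source may bear on it.

Working notes on the series. In a functional assay (aorta) with Rattus norvegicus as the target (a higher number here means a more potent compound, by a factor of ten per unit of this negative logarithm, a lower number a less potent compound), compound 1 `CC(=O)c1ccc2c(c1)C(n1ccccc1=O)=CC(C)(C)O2` gives 7.37. Within the data shown here, compound 2 `CC1(C)C=C(n2ccccc2=O)c2cc(C(=O)c3cccs3)ccc2O1` gives 6.4 in this assay, the lowest of the two numbers so far, with compound 1 standing higher. Among the measured compounds shown here, the one step measured within the pair is a number 0.97 log units lower from compound 1 to compound 2 (beyond the scatter), so swapping the methyl on the carbonyl carbon for an aromatic ring cost potency in this assay. Compound 3 `CC1(C)C=C(n2ccccc2=O)c2cc(C(=O)c3ccc(O)cc3)ccc2O1` differs from compound 2 as follows: 4-hydroxyphenyl in place of thiophen-2-yl on a carbonyl carbon. For the measured compounds named here, no measured step exchanges one aromatic ring for another on this carbonyl carbon, so the only bearing comes from compound 1 and compound 2, which show that the group on the carbonyl carbon does move this assay by a modest amount. Compound 3 is therefore expected to stay near compound 2, with a small step of a number 0.20 log units higher from compound 2 to compound 3 (within the scatter) upward in this assay. The estimate for compound 3 is 6.6, within 5.9 to 7.3.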

Compound 3, logarithm of the reciprocal of the active concentration, log(1/C): 6.65
The estimate for compound 3 lay 0.05 log units below the measured number; the measured number falls inside the stated range.
By their numbers in this assay, from the lowest: compounds 2 and 3 (each within the scatter of the next); then compound 1.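

The step of a number 0.25 log units higher from compound 2 to compound 3 (within the scatter) means that in this assay thiophen-2-yl and 4-hydroxyphenyl on this carbonyl carbon cannot be told apart, despite the change in ring size and the hydroxyl that comes in with 4-hydroxyphenyl. The fall seen on leaving methyl is therefore not confined to thiophen-2-yl, since the step of a number 0.72 log units lower from compound 1 to compound 3 (beyond the scatter) shows it again with a six-membered aromatic ring of carbon only. No measurement available here explains either step.

The compounds shown leave open whether the higher number belongs to methyl alone or extends to other saturated groups on the carbonyl carbon, such as ethyl or cyclopropyl. Also open, going by these compounds, is whether the hydroxyl matters at all, a question that plain phenyl or 4-methoxyphenyl would bear on.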